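Swapping 4-chlorophenyl for 2-methylphenyl on a shared core

This account rests on a few compounds, and the source may have more. Where it says the series, first, only, none or still open, it means among the compounds named here.

Of the compounds shown here, three have been measured in a functional assay on A549 cells (Homo sapiens) for cytotoxicity, read by sulforhodamine B assay; a higher number here means a weaker inhibitor, a lower number a stronger inhibitor. Compound 1 (`Oc1nc(-c2ccccc2)cc2ccccc12`) gives 5750 nM, compound 2 (`Cc1ccc(-c2cc3cc(C)ccc3c(O)n2)cc1`) gives 5620 nM, and compound 3 (`Cc1ccc2c(N3CCN(C)CC3)nc(-c3ccc(Cl)cc3)cc2c1`) gives 3190 nM. Compound 3 stands level with the other two, since its gap to each lies within the usual scatter of repeated measurements.

Compound 4 (`Cc1ccc2c(N3CCN(C)CC3)nc(-c3ccccc3C)cc2c1`) has not yet been measured. It carries 2-methylphenyl in place of 4-chlorophenyl on an aromatic carbon next to the ring nitrogen: 2-methylphenyl in place of 4-chlorophenyl on an aromatic carbon. Going by the values given here, no two measured compounds differ in just one place, so the data offer no direct guide to this swap. Even so, compound 1 at 5750 nM and compound 3 at 3190 nM differ in more than one place and still sit within the scatter of each other. A step beyond the scatter in this assay is therefore not expected. The estimated change is a 1.3-fold higher number from compound 3 to compound 4 (0.10 log units; within the scatter). Compound 4 is expected at 4000 nM, with an estimated range of 1500 nM to 10000 nM.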

Compound 4, half-maximal inhibitory concentration: 7590 nM
Compound 4: middle estimate off by 1.9-fold (0.28 log units), on the low side; measured number inside the range.
By their numbers in this assay, from the lowest: compounds 3, 2, 1 and 4 (each within the scatter of the next, the first and the last beyond it).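

In this assay, placing 2-methylphenyl instead of 4-chlorophenyl on the aromatic carbon next to the ring nitrogen gives a 2.4-fold higher number from compound 3 to compound 4 (0.38 log units; beyond the scatter). Going by these compounds alone, this is the first comparison in the set that changes only one place, and it shows that this position responds to the choice of aryl group: the swap weakens inhibition by more than the scatter, even though both groups have the same heavy-atom count and one six-membered aromatic ring of carbon only. No measurement at hand explains this difference.

The swap changes both the substituent and where it sits on the phenyl ring, so 2-chlorophenyl or 4-methylphenyl on this same core would be needed to tell those two changes apart. As far as these compounds go, how an aminophenyl group or a pyridyl ring would fare at this position also remains open.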